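A few compounds are considered here, and "the series" means these few. Any claim that something is new, unique, unknown or untested is made for them only; others in the source may bear on it.

Measured compounds in a functional assay on PC-3 cells (Homo sapiens) for cytotoxicity, read by MTT assay, with a stated time of 72 h; on this read-out higher numbers stand for weaker inhibition and lower numbers for stronger inhibition: compound 1 `COc1cc(Nc2nc3ccccc3nc2S(=O)(=O)c2ccccc2)cc(OC)c1` gives 140 nM; compound 2 `COc1cc(Nc2nc3ccccc3nc2S(=O)(=O)c2ccccc2)cc(OC)c1OC` gives 29100 nM; compound 3 `COc1ccc(S(=O)(=O)c2nc3ccccc3nc2Nc2ccc(C(F)(F)F)cc2)cc1` gives 330 nM.

Compound 2 stands at the highest number of the three. Compound 3 comes nearest, and compound 1 lies furthest, at the lowest number of the set. Among the compounds with values here, the one single-point step among the measured compounds is a 210-fold higher number from compound 1 to compound 2 (2.32 log units; beyond the scatter), brought about by a methoxy in place of hydrogen on an aromatic carbon; this is a large step and it sets where compound 2 starts from.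

Compound 4 `COc1cc(Nc2nc3ccccc3nc2S(=O)(=O)c2ccc(F)cc2)cc(OC)c1OC` differs from compound 2 by fluoro in place of hydrogen on an aromatic carbon. Within the data shown here, no measured pair changes the same place: compound 3 carries a methoxy on the phenylsulfonyl ring but also a different group on the aniline, so its value against compound 1 or compound 2 cannot be read as one step. The change is a single small atom, no ring, no donor or acceptor. Nothing in the set argues for a move beyond the scatter, so the expected step of a 1.2-fold lower number from compound 2 to compound 4 (0.07 log units; within the scatter) is small, direction uncertain. Compound 4 is therefore estimated at 25000 nM in this assay, with a range from 8000 nM to 80000 nM.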

Compound 4, half-maximal inhibitory concentration: > 50000 nM
Compound 4: no number, only a limit (the forecaster's own chance of this, stated with the estimate: 10%); middle value at least 2.0-fold (0.30 log units) from the limit.
By their numbers in this assay, from the lowest: compound 1; then compound 3; then compound 2. At a limit, above all of these: compound 4.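

In this assay compound 4 reads > 50000 nM, which is a limit of the assay and not a number: the limit of > 50000 nM in this assay, at which 1 of the 4 values shown sits.

Within the data shown here, this gives the first single-place reading on the phenylsulfonyl ring, since the only step among the earlier compounds, a 210-fold higher number from compound 1 to compound 2 (2.32 log units; beyond the scatter), lies on the aniline side. Here the step is an at least 1.7-fold higher number from compound 2 to compound 4 (0.23 log units; that floor lies within the scatter), so only a floor is available, and the true size of the change from phenylsulfonyl to (4-fluorophenyl)sulfonyl stays unfixed. What can be said is that on the background of compound 2, fluoro at this place brings no move to a lower number.

Still open, on these data alone, is how the same fluoro would read on the background of compound 1, where a value of 140 nM leaves room to see a change in either direction. Also open, as far as these compounds go, is how an amine or a carboxylic acid would read at this place on the ring, on the background of compound 1 rather than that of compound 2.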